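Moving a Trifluoromethoxy Group in a Sulfonyl Series

This account rests on a few compounds, and the source may have more. Where it says the series, first, only, none or still open, it means among the compounds named here.

Compound 1 `CC(O)(CS(=O)(=O)c1ccc(OC(F)(F)F)cc1)C(=O)Nc1ccc(S(F)(F)(F)(F)F)cc1` gives 51900 nM in a functional assay on CWR22R cells (Homo sapiens) for antiproliferative activity, read by propidium iodide staining, with a stated time of 96 h; on this read-out lower numbers stand for stronger inhibition and higher numbers for weaker inhibition. Compound 2 `CC(O)(CS(=O)(=O)c1cccc(OC(F)(F)F)c1)C(=O)Nc1ccc(S(F)(F)(F)(F)F)cc1` gives 22400 nM in this assay, and the change between them, (3-(trifluoromethoxy)phenyl in place of 4-(trifluoromethoxy)phenyl on a sulfonyl sulfur), brought a 2.3-fold lower number from compound 1 to compound 2 (0.36 log units; beyond the scatter). Compound 3 `CC(O)(CS(=O)(=O)c1ccc(OC(F)(F)F)cc1)C(=O)Nc1cccc(S(F)(F)(F)(F)F)c1` has the same atoms as compound 1 joined differently; the difference between the two cores is not broken down here. In this assay compound 3 gives 31200 nM. Compound 4 `CC(O)(CS(=O)(=O)c1cccc(OC(F)(F)F)c1)C(=O)Nc1cccc(S(F)(F)(F)(F)F)c1` has not yet been measured; it differs from compound 3 by 3-(trifluoromethoxy)phenyl in place of 4-(trifluoromethoxy)phenyl on a sulfonyl sulfur, the same change at the same place as from compound 1 to compound 2. Going by the values given here, a step of similar size is expected, a 2.1-fold lower number from compound 3 to compound 4 (0.32 log units; beyond the scatter), because the earlier matching change gave a 2.3-fold lower number from compound 1 to compound 2 (0.36 log units; beyond the scatter), although the cores differ and only one earlier example exists. The expected value for compound 4 in this assay is 15000 nM, roughly between 6000 nM and 40000 nM.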

Compound 4, half-maximal inhibitory concentration: 20100 nM
Beside the measured number, compound 4's estimate is 1.3-fold (0.13 log units) below it, within the range that was stated.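

In this assay, putting 3-(trifluoromethoxy)phenyl in place of 4-(trifluoromethoxy)phenyl on the sulfonyl sulfur of the second core gives a 1.6-fold lower number from compound 3 to compound 4 (0.19 log units; within the scatter). Set beside the earlier step, the two results cannot be told apart: the same change on two cores in this assay, a 2.3-fold lower number (0.36 log units; beyond the scatter) from compound 1 to compound 2 and a 1.6-fold lower number (0.19 log units; within the scatter) from compound 3 to compound 4, 1.5-fold (0.17 log units) apart, within the scatter of two such steps. This agrees with the change carrying over between these two cores, but two pairs are too few to establish a rule, and on the second core the step alone cannot be told from scatter.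

The compounds shown leave open whether the change would carry over to further cores. They also leave open what an amine or a carboxylic acid would do in place of the trifluoromethoxy group.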